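Phenyl to Isopropyl: What to Expect for Compound 4

The source may hold more compounds than are shown below. What is called first, only, known or untested is meant among the compounds shown, and "the series" means these compounds.

Compound 1 `Cc1sc(-c2ccccc2)cc1-c1cc(C(N)=O)nn1C`: 1200 nM
Compound 2 `Cc1sc2ccccc2c1-c1cc(C(N)=O)nn1C`: 851 nM
Compound 3 `Cc1sc(-c2ccccc2)cc1-c1cc(C(N)=O)n[nH]1`: 347 nM

In an assay on isolated protein for inhibition of Group 10 secretory phospholipase A2 (Homo sapiens), with a stated time of 30 min (a higher number here means a weaker inhibitor, a lower number a stronger inhibitor), compound 3 gives the lowest number of the three. Among the measured compounds shown here, the one single-point step measured so far, a 3.5-fold lower number from compound 1 to compound 3 (0.54 log units; beyond the scatter), concerns the hydrogen on the aromatic nitrogen, not the group examined here. Compound 2 differs from the others in more than one place, so its value only shows that it lies between the two.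

Compound 4 `Cc1sc(C(C)C)cc1-c1cc(C(N)=O)n[nH]1` arises from compound 3 by isopropyl in place of phenyl on an aromatic carbon. For the measured compounds named here, no measured step touches this change, so nothing in the data predicts its direction or size; a modest shift either way is plausible. Compound 4 is therefore expected at about 700 nM, within 200 nM to 2500 nM. That estimate corresponds to a 2.0-fold higher number from compound 3 to compound 4 (0.30 log units; within the scatter).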

Compound 4, half-maximal inhibitory concentration: < 51.3 nM
Compound 4: no number, only a limit (the forecaster's own chance of this, stated with the estimate: 5%); middle value at least 13-fold (1.13 log units) from the limit.
By their numbers in this assay, from the lowest: compound 3; then compounds 2 and 1 (each within the scatter of the next). At a limit, below all of these: compound 4.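

In this assay, this carbon next to the ring sulfur does not need phenyl: isopropyl, with no ring and fewer heavy atoms, gives an at least 6.7-fold lower number from compound 3 to compound 4 (0.83 log units; beyond the scatter). Among the compounds shown here, that is the first sign that the group here can shift the number strongly, at least for this pair. For compound 4 the result is a limit of the assay, not a number: the limit of < 51.3 nM in this assay, at which 1 of the 4 values shown sits.

As far as these compounds go, whether an ethyl, a cyclopropyl or a tert-butyl group at this carbon would give a lower or higher number remains open. So does whether the step seen on the aromatic nitrogen would repeat with isopropyl in place.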